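Chain change on the ring nitrogen of compound 3

This account rests on a few compounds, and the source may have more. Where it says the series, first, only, none or still open, it means among the compounds named here.

Compound 1 `CCC(C)(C)c1ccc2nc(N)sc2c1` and compound 2 `Nc1nc2cc(OC(F)(F)F)ccc2s1` carry no chain on the ring nitrogen. In a functional assay on the whole organism with Rattus norvegicus as the target (on this read-out lower numbers stand for an effect already at smaller amounts and higher numbers for an effect only at larger amounts of compound), compound 1 gives only a limit, > 10 mg/kg, not a number. Compound 2 likewise gives only a limit in this assay, > 10 mg/kg. For the measured compounds named here, compound 3 `CCCn1c(=N)sc2cc(OC(F)(F)F)ccc21` is the one member with a measured number: in this assay compound 3 gives 4.5 mg/kg, so compound 3 stands as the sole numbered point of the three, the other two resting at the limit of > 10 mg/kg in this assay, at which 2 of the 3 values shown sit. Compound 4 `C[S+]([O-])Cn1c(=N)sc2cc(OC(F)(F)F)ccc21` is not yet measured. It differs from compound 3 in one place (a group of 3 heavy atoms (1 carbon, 1 oxygen, 1 sulfur; no ring) in place of a group of 2 heavy atoms (2 carbon; no ring), on a saturated chain carbon bound to an aromatic nitrogen). Going by the values given here, no step between measured compounds exists to set the size of such a change, and the two limits give no direction. The expected step in this assay is a 1.8-fold higher number from compound 3 to compound 4 (0.25 log units; within the scatter), toward larger amounts, only just beyond the scatter. Compound 4 is expected to give 8 mg/kg in this assay, with a range from 3 mg/kg to 20 mg/kg.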

Compound 4, dose for half-maximal effect: 2.3 mg/kg
Estimate against measurement, compound 4: 3.5-fold (0.54 log units) above; the measured number lies below the stated range.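

In this assay, the exchange of ethyl for the sulfur- and oxygen-bearing group gives a 2.0-fold lower number from compound 3 to compound 4 (0.29 log units; within the scatter), so compound 3 and compound 4 cannot be told apart. For the compounds shown here, this is the only step at this place, and it shows that a chain carrying 1 hydrogen-bond acceptor, on a saturated chain carbon bound to an aromatic nitrogen, keeps a measured number of the same order as the ethyl compound. Compound 1 and compound 2, which have no chain on the ring nitrogen, give limits rather than numbers, so what the chain itself contributes cannot be sized: the limit of > 10 mg/kg in this assay, at which 2 of the 4 values shown sit.

One step within the scatter does not set a trend for this place. Open, going by these compounds, are the thioether without the oxygen on sulfur, the sulfone, a longer chain, and an amine or a carboxylic acid at the chain end.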